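Methoxy for Methyl on a Cytotoxicity Core

This account rests on a few compounds, and the source may have more. Where it says the series, first, only, none or still open, it means among the compounds named here.

Measured in an ADME assay on TERT-RPE1 cells (Homo sapiens) for cytotoxicity, read by MTT assay, with a stated time of 72 h; on this read-out higher numbers stand for weaker inhibition and lower numbers for stronger inhibition:
- compound 1 `COc1ccc(/C=C2/CN(C)/C(=N/c3ccc(C)cc3)S2)cc1` gives 65700 nM
- compound 2 `COc1ccc(/C=C2\S/C(=N\c3ccc(C(C)(C)C)cc3)N(C)C2=O)cc1` gives 46700 nM
- compound 3 `COc1ccc(/C=C2\S/C(=N\c3ccccc3)N(C)C2=O)cc1` gives > 100000 nM, which is a limit of the assay and not a number.

Compound 1 and compound 2 lie within the usual scatter of each other, so their two numbers cannot be told apart. Among the measured compounds shown here, the only step measured so far is an at least 2.1-fold higher number from compound 2 to compound 3 (0.33 log units; beyond the scatter), and its end point is only a limit, namely (the limit of > 100000 nM in this assay, at which 1 of the 3 values shown sits). The next compound, compound 4 `COc1ccc(/C=C2/CN(C)/C(=N/c3ccc(OC)cc3)S2)cc1`, differs from compound 1 by methoxy in place of methyl on an aromatic carbon. For the measured compounds named here, no measured step exchanges one small group for another at a place of this kind; the single measured step puts hydrogen in place of tert-butyl and reaches a limit rather than a number, so it gives only a weak hint that a group at such a place can matter. The expectation for compound 4 in this assay is therefore no shift beyond the scatter, a 1.1-fold higher number from compound 1 to compound 4 (0.03 log units; within the scatter), with an estimated value of 70000 nM and a range from 30000 nM to 150000 nM.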

Compound 4, half-maximal inhibitory concentration: 65900 nM
For compound 4 the middle estimate is 1.1-fold (0.03 log units) above the measured one; measured number inside the range.
By their numbers in this assay, from the lowest: compounds 2, 1 and 4 (each within the scatter of the next). At a limit, above all of these: compound 3.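

In this assay, among the compounds shown here, methoxy in place of methyl gives a 1.0-fold higher number from compound 1 to compound 4 (0.00 log units; within the scatter) on an otherwise unaltered core, and this is the first measured exchange of one small group for another at this place. The 4-methylphenyl and 4-methoxyphenyl compounds therefore cannot be told apart here, even though the group that enters brings an oxygen and a hydrogen-bond acceptor. Nothing shown explains why these two groups give such similar numbers.

Going by these compounds, it remains open whether this place accepts any group on this core or only these two, since a far larger group, an amine or a carboxylic acid could still give a different result. On these data alone, the core of compound 1 also lacks a measured partner with plain hydrogen at this place, so the effect of having no group there is unknown.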